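The source may report more compounds than this note shows. Statements on the series, on what has been measured and on what is new or still open speak of the compounds shown alone.

Measured compounds:
compound 1 `O=c1oc2ccccc2c2nc3c(ccc4cc[nH]c43)c(-c3cccc4ccccc34)c12` — 70700 nM
compound 2 `Cc1ccc(-c2c3ccc4cc[nH]c4c3nc3c2c(=O)oc2ccccc23)cc1` — 70700 nM

In a functional assay on B16-F10 cells (Mus musculus) for cytotoxicity (on this read-out lower numbers stand for stronger inhibition and higher numbers for weaker inhibition), compound 2 gives 70700 nM. It stands level with compound 1, which gives 70700 nM; the step of no change at the digits printed from compound 1 to compound 2 (within the scatter) covers a change of the aryl group on the shared core, 4-methylphenyl in place of naphthalen-1-yl on an aromatic carbon, and left the read-out where it was.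

Compound 3 `O=c1oc2ccccc2c2nc3c(ccc4cc[nH]c43)c(-c3cccc(Cl)c3Cl)c12` is the next member. Its difference from compound 2 is 2,3-dichlorophenyl in place of 4-methylphenyl on an aromatic carbon.

Within the data shown here, only one measured step bears on this change: the aryl swap from compound 1 to compound 2, no change at the digits printed from compound 1 to compound 2 (within the scatter), which stayed within the scatter although the two aryl groups differ considerably in size. Among the measured compounds shown here, nothing measured so far shows the read-out moving with the aryl group at this position, and no compound carrying chlorine on that ring has been measured. The expectation for compound 3 is therefore a step of no change at the digits printed from compound 2 to compound 3 (within the scatter), that is, no change beyond the scatter. Compound 3 is estimated at 70700 nM, with a range from 35000 nM to 141000 nM.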

Compound 3, half-maximal inhibitory concentration: 70700 nM
Compound 3: middle estimate and measured number agree at the digits printed; the measured number falls inside the stated range.
By their numbers in this assay, from the lowest: compounds 1, 2 and 3 (each within the scatter of the next).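

In this assay, among these compounds, the step of no change at the digits printed from compound 2 to compound 3 (within the scatter) gives the first reading at this aromatic carbon, opposite the ring nitrogen, for an aryl group carrying chlorine, and the step of no change at the digits printed from compound 1 to compound 3 (within the scatter) compares that group directly with naphthalen-1-yl. Across naphthalen-1-yl, 4-methylphenyl and 2,3-dichlorophenyl, the read-out therefore does not separate a methyl-bearing ring from a ring with two chlorine atoms, nor either of these from the fused naphthalene group. The earlier pair covered only a change of aryl size and shape, whereas this result extends the flat reading to a change in the ring's substituents, though only for these three groups, and no measurement at hand bears on why the read-out holds across them.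

On these data alone, all three groups are aryl rings of carbon only, so it remains open whether a morpholine, a dimethylamine or a carboxylic acid at this carbon, or a pyridine ring in place of the aryl ring, would move the read-out. As far as these compounds go, it also remains open whether a hydroxyl or an amine placed elsewhere on the shared core would shift the read-out.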